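A new ring where only limits have been measured

This account rests on a few compounds, and the source may have more. Where it says the series, first, only, none or still open, it means among the compounds named here.

In an ADME assay on Raji cells (Homo sapiens) for cytotoxicity, read by luminescence, with a stated time of 72 h (on this read-out lower numbers stand for an effect already at smaller amounts and higher numbers for an effect only at larger amounts of compound), compound 1 `CCOC(=O)c1c(-c2cc(F)cc(OC)c2)[nH]c2cc(OC)ccc2c1=O` gives > 21500 nM as a limit and not a number. Compound 2 `CCOC(=O)c1c(-c2cccc(OC(F)(F)F)c2)[nH]c2cc(OC)ccc2c1=O` gives > 21500 nM which is again a limit. Compound 3 `CCOC(=O)c1c(-c2cccc(OC(F)(F)F)c2)[nH]c2cc(OC)c(F)cc2c1=O` gives > 21500 nM and this too is only a limit. Compound 3 therefore has no exact place on the scale, and the other two compounds offer no number to compare it with. For the measured compounds named here, the one measured step is a step that the two limits leave unreadable from compound 2 to compound 3 for fluoro in place of hydrogen on an aromatic carbon, and it provides no size to carry forward. The whole record is the limit of > 21500 nM in this assay, at which 3 of the 3 values shown sit, and nothing more.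

Going by the values given here, compound 4 `CCOC(=O)c1c(-c2cccc(-c3nc(C)c(C)s3)c2)[nH]c2cc(OC)c(F)cc2c1=O` brings a different change, 4,5-dimethyl-1,3-thiazol-2-yl in place of trifluoromethoxy on an aromatic carbon and no measured step covers this swap. Since compound 3 rests at > 21500 nM as a limit, the expectation is no step beyond the scatter, in either direction, with another limit the likeliest report. The estimated change is a step that the limit leaves unreadable from compound 3 to compound 4 under this expectation. For compound 4 the expected value is about 22000 nM with an estimated range from 8000 nM to 50000 nM in this assay on present evidence.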

Compound 4, half-maximal effective concentration: > 21500 nM
Compound 4 gave a limit, no number; the forecaster's own chance of this, stated with the estimate: 75%; the middle value does not contradict the limit.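

In this assay, for the compounds shown here, compound 4 gives > 21500 nM, again a limit and not a number, so the change from compound 3 to compound 4 yields no step that can be read. The compounds shown leave open how they rank against one another and at what concentration any of them would show an effect: the limit of > 21500 nM in this assay, at which 4 of the 4 values shown sit.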